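The source may report more compounds than this note shows. Statements on the series, on what has been measured and on what is new or still open speak of the compounds shown alone.

Working notes on the series. In an ADME assay on HCT-116 cells (Homo sapiens) for cytotoxicity, read by CellTiter-Glo, with a stated time of 72 h (a higher number here means a weaker inhibitor, a lower number a stronger inhibitor), compound 1 `Cc1noc(C)c1S(=O)(=O)N1CCC(N2CCC(C)CC2)CC1` gives > 10000 nM, which is a limit of the assay. Compound 2 `CC1CCN(C2CCN(S(=O)(=O)c3ccc(Cl)nc3)CC2)CC1` gives > 10000 nM, also a limit and not a number. Both measured compounds therefore stand at the limit of > 10000 nM in this assay, at which 2 of the 2 values shown sit. Compound 3 `CC1CCN(C2CCN(S(=O)(=O)c3cn(C)cn3)CC2)CC1` differs from compound 2 by one change on the sulfonyl sulfur: 1-methyl-1H-imidazol-4-yl in place of 6-chloropyridin-3-yl on a sulfonyl sulfur. Within the data shown here, the only measured step is a step that the two limits leave unreadable from compound 1 to compound 2, so it supplies no size to carry over. The estimated step, a step that the limit leaves unreadable from compound 2 to compound 3, is expected to be none beyond the scatter in this assay. The expected value for compound 3 is 12000 nM, with an estimated range of 5000 nM to 30000 nM.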

Compound 3, half-maximal inhibitory concentration: > 10000 nM
Compound 3 was reported as a limit; the forecaster's own chance of this, stated with the estimate: 85%; the middle value does not contradict the limit.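

No step can be read between compound 1, compound 2 and compound 3 in this assay, as each result is a limit and not a number: the limit of > 10000 nM in this assay, at which 3 of the 3 values shown sit.

The compounds shown leave open whether any group on the sulfonyl sulfur gives a numerical value in this assay.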